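Anilinoquinazoline thioethers: swapping the aniline substituent

A few compounds are considered here, and "the series" means these few. Any claim that something is new, unique, unknown or untested is made for them only; others in the source may bear on it.

Measured so far in a functional assay on MCF7 cells (Homo sapiens) for cytotoxicity, read by MTT assay, with a stated time of 72 h; a higher number here means a weaker inhibitor, a lower number a stronger inhibitor:
- compound 1 `FC(F)(F)c1ccc(CSc2nc(Nc3ccccc3)c3ccccc3n2)cc1`: 44000 nM
- compound 2 `FC(F)(F)c1ccc(CSc2nc(Nc3ccccc3C(F)(F)F)c3ccccc3n2)cc1`: > 50000 nM
- compound 3 `O=[N+]([O-])c1ccc(Nc2nc(SCc3ccc(C(F)(F)F)cc3)nc3ccccc23)cc1`: 17900 nM

Compound 2 sits at the weak end of the three. Its entry in this assay is a limit, not a number, and that limit is the limit of > 50000 nM in this assay, at which 1 of the 3 values shown sits. Compound 4 `CCOc1ccc(Nc2nc(SCc3ccc(C(F)(F)F)cc3)nc3ccccc23)cc1` has not yet been measured; it differs from compound 2 as follows: 4-ethoxyphenyl in place of 2-(trifluoromethyl)phenyl on a nitrogen on an aromatic ring.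

Within the data shown here, two measured steps bear on this. Adding trifluoromethyl gave an at least 1.1-fold higher number from compound 1 to compound 2 (0.05 log units; that floor lies within the scatter). Replacing the same ring with 4-nitrophenyl gave an at least 2.7-fold lower number from compound 2 to compound 3 (0.44 log units; beyond the scatter), and nitro alone gave a 2.5-fold lower number from compound 1 to compound 3 (0.39 log units; beyond the scatter). Leaving the 2-(trifluoromethyl)phenyl group has therefore so far meant a lower number, by a modest amount. Among the measured compounds shown here, a 4-ethoxyphenyl group has no measured precedent, so the size of the step is uncertain, and the direction is taken from compound 3 only.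

Compound 4 is therefore expected to give about 25000 nM, with a range of 8000 nM to 60000 nM. This amounts to an expected step of an at least 2.0-fold lower number from compound 2 to compound 4 (0.30 log units; that floor lies within the scatter).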

Compound 4, half-maximal inhibitory concentration: > 50000 nM
Compound 4 ended at the assay's limit (the forecaster's own chance of this, stated with the estimate: 25%); middle value at least 2.0-fold (0.30 log units) away from the limit.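

In this assay, ethoxy in place of nitro gave an at least 2.7-fold higher number from compound 3 to compound 4 (0.44 log units; beyond the scatter), so the lower number seen with 4-nitrophenyl does not extend to 4-ethoxyphenyl on the same nitrogen. Ethoxy in place of hydrogen gave an at least 1.1-fold higher number from compound 1 to compound 4 (0.05 log units; that floor lies within the scatter), so compound 4 shows no gain over the unsubstituted phenyl of compound 1. Compound 2 and compound 4 both stand as limits, so the step between them cannot be read: the limit of > 50000 nM in this assay, at which 2 of the 4 values shown sit.

Among the compounds shown, nitro is the only substituent with a step to a lower number beyond the scatter, and it remains open whether a nitrile, an amine or a carboxylic acid on this ring would behave like nitro or like ethoxy. On these data alone, how far compound 2 and compound 4 lie past the limit also remains open.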